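The compounds below may be only part of what the source reports. "The series", "measured", "known", "first", "only" and "open" are said of these compounds alone.

Compound 1, `Cc1ccc(N(C(=O)c2ccccc2[N+](=O)[O-])C(=S)OCCN2C(=O)c3ccccc3C2=O)cc1`, gives 100000 nM in an ADME assay on MT4 cells (Homo sapiens) for cytotoxicity, read by MTT assay; on this read-out lower numbers stand for higher toxicity in this test and higher numbers for lower toxicity in this test.
Compound 2, `Cc1ccc(N(C(=O)c2cccc([N+](=O)[O-])c2)C(=S)OCCN2C(=O)c3ccccc3C2=O)cc1`, gives 100000 nM in this assay.
Compound 3, `O=C1c2ccccc2C(=O)N1CCOC(=S)N(C(=O)c1ccc(F)cc1F)c1ccc(Cl)cc1`, gives 52000 nM in this assay.

Compound 3 has the lowest of the three numbers, yet both other values lie within the usual scatter of it, so the three compounds cannot be told apart on this read-out. Compound 4, `O=C1c2ccccc2C(=O)N1CCOC(=S)N(C(=O)c1cc(Cl)cc(Cl)c1)c1ccc(Cl)cc1`, differs from compound 3 in one place: 3,5-dichlorophenyl in place of 2,4-difluorophenyl on a carbonyl carbon. Among the measured compounds shown here, no measured step exchanges exactly these two groups, so the expectation rests on analogy alone. For the measured compounds named here, the one measured step, no change at the digits printed from compound 1 to compound 2 (within the scatter), also exchanged the group on a carbonyl carbon and left the number unchanged within the scatter. On that basis the step of a 1.3-fold higher number from compound 3 to compound 4 (0.10 log units; within the scatter) is expected to stay within the scatter, with no clear direction, and the wide gap between a number and a possible plateau of the test adds uncertainty. Compound 4 is therefore estimated at 65000 nM, within a range from 28000 nM to 110000 nM.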

Compound 4, half-maximal cytotoxic concentration: 32000 nM
Estimate against measurement, compound 4: 2.0-fold (0.31 log units) above; low and high end bracket the measured number.
By their numbers in this assay, from the lowest: compounds 4, 3, 1 and 2 (each within the scatter of the next, the first and the last beyond it).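

Putting 3,5-dichlorophenyl in place of 2,4-difluorophenyl on this carbonyl carbon gives a 1.6-fold lower number from compound 3 to compound 4 (0.21 log units; within the scatter) in this assay and so adds a second exchange at this position that stays within the scatter. The earlier step, no change at the digits printed from compound 1 to compound 2 (within the scatter) in the same test, only swapped 2-nitrophenyl for 3-nitrophenyl, whereas this exchange alters both the halogen and the ring positions it occupies, so the two contributions cannot be separated. No measurement at hand offers an explanation for this step.

Every group shown at this carbonyl carbon is a phenyl ring bearing nitro or halogen groups, so it stays open whether a phenyl ring carrying an amine or a carboxylic acid would also stay within the scatter. Equally open, on these data alone, is what a longer chain on the oxygen would do to the number.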